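Swapping the aryl on the ring nitrogen of compound 2

This account rests on a few compounds, and the source may have more. Where it says the series, first, only, none or still open, it means among the compounds named here.

Of the compounds shown here, two sharing one core have been measured in a functional assay on MCF7 cells (Homo sapiens) for cytotoxicity, read by MTT assay, with a stated time of 72 h; on this read-out lower numbers stand for stronger inhibition and higher numbers for weaker inhibition. Compound 1 `O=C(Nc1ccc(Oc2ccnc3[nH]ccc23)cc1)c1nn(-c2ccc(Cl)c(C(F)(F)F)c2)ccc1=O` gives 6270 nM in this assay. Compound 2 `O=C(Nc1ccc(Oc2ccnc3[nH]ccc23)c(F)c1)c1nn(-c2ccc(Br)cc2F)ccc1=O` gives 23500 nM, the higher of the two numbers, and the gap to compound 1 is beyond the scatter. Compound 3 `O=C(Nc1ccc(Oc2ccnc3[nH]ccc23)c(F)c1)c1nn(-c2ccc(Cl)c(C(F)(F)F)c2)ccc1=O` has not yet been measured. It keeps the core of compound 2 and differs from it in one place: 4-chloro-3-(trifluoromethyl)phenyl in place of 4-bromo-2-fluorophenyl on an aromatic nitrogen. Within the data shown here, the entering group is the one that compound 1 carries, and compound 1 is the weaker-numbered of the two measured compounds in this assay, so the change is expected to move the number downward by a step beyond the scatter, as a 2.9-fold lower number from compound 2 to compound 3 (0.47 log units; beyond the scatter) indicates. Compound 3 is therefore estimated at 8000 nM in this assay, within a range from 3000 nM to 25000 nM.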

Compound 3, half-maximal inhibitory concentration: 11600 nM
Beside the measured number, compound 3's estimate is 1.5-fold (0.16 log units) below it, and the stated range covers the measured number.
By their numbers in this assay, from the lowest: compounds 1 and 3 (each within the scatter of the next); then compound 2.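

In this assay, the aryl on the aromatic nitrogen now has a step of its own: with the rest of compound 2 kept, 4-chloro-3-(trifluoromethyl)phenyl in place of 4-bromo-2-fluorophenyl gives a modest change (a 2.0-fold lower number from compound 2 to compound 3 (0.31 log units; beyond the scatter)). Among these compounds, the fluoro on an aromatic carbon, the one place where compound 1 and compound 3 differ, gives a step that stays within the scatter (a 1.9-fold higher number from compound 1 to compound 3 (0.27 log units; within the scatter)), so with this aryl its effect cannot be told from repeat variation. No measurement is at hand that would account for either step.

The swap exchanges all the substituents on the aryl at once, so these compounds cannot show which of them carries the step. On these data alone, how a methoxy group, a nitrile or an amine on that ring would read also remains open.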